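A few compounds are considered here, and "the series" means these few. Any claim that something is new, unique, unknown or untested is made for them only; others in the source may bear on it.

Compound 1 `CC#CCn1c(N2CCC[C@@H](N)C2)nc2c1c(=O)n(Cc1ccc(Br)cc1C(=O)O)c(=O)n2C` and compound 2 `CC#CCn1c(N2CCC[C@@H](N)C2)nc2c1c(=O)n(Cc1ccc(Cl)cc1C(=O)O)c(=O)n2C` share the same core. In a physicochemical assay for metabolic stability, read by LC-MS, in phosphate buffer, with a stated time of 120 min, at pH 7.4, tested at 1 uM (on this read-out higher numbers stand for a more stable compound and lower numbers for a less stable compound), compound 1 gives 99.2% and compound 2 gives 101%, so the two cannot be told apart on this measure. Compound 3 `CC#CCn1c(N2CCC[C@@H](N)C2)nc2c1c(=O)n(Cc1ccc(Cl)cc1C(=O)OC)c(=O)n2C` differs from compound 2 in one place: methyl in place of hydrogen on an oxygen next to a carbonyl group. This is methyl in place of hydrogen on an oxygen next to a carbonyl group, which turns carboxy into methoxycarbonyl. For the measured compounds named here, the only measured step, a number 1.8 percentage points higher from compound 1 to compound 2 (within the scatter), is chloro in place of bromo on an aromatic carbon, a different change that leaves the carboxy group untouched. Going by the values given here, no measured compound carries methoxycarbonyl, so the data give no direct guide. With compound 2 at 101% there is little room upward in this assay, so a small loss, possibly no larger than the scatter, is expected. The expected step is a number 8 percentage points lower from compound 2 to compound 3 (within the scatter). For compound 3 the estimated value is 93%, with an expected range from 76% to 103%.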

Compound 3, percent of the compound remaining: 101%
Estimate against measurement, compound 3: 8 percentage points below; the measured number falls inside the stated range.
By their numbers in this assay, from the lowest: compounds 1, 2 and 3 (each within the scatter of the next).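

On the oxygen of the carboxy group, methyl in place of hydrogen gives methoxycarbonyl, and this change comes with no change at the digits printed from compound 2 to compound 3 (within the scatter) in this assay. Until now this position had been seen only as carboxy; it can also carry methoxycarbonyl without a difference that this measure can read. The step that alters both the halogen and this group, a number 1.8 percentage points higher from compound 1 to compound 3 (within the scatter), joins two changes in one, so it cannot be assigned to either, and nothing at hand explains these results.

As far as these compounds go, whether a longer ester such as ethoxycarbonyl, a primary amide or a nitrile would read the same at this position remains open. So does whether methoxycarbonyl would behave the same way with bromo in place of chloro on the ring.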